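A Nitro Group in Place of Hydroxy on a Weak Series

A few compounds are considered here, and "the series" means these few. Any claim that something is new, unique, unknown or untested is made for them only; others in the source may bear on it.

Compound 3 `COc1cc(-c2nnc3n2NC(c2ccco2)C(C(=O)c2ccc(O)cc2)S3)cc(OC)c1OC` carries a 4-hydroxyphenyl on the carbonyl carbon of the shared core. In a functional assay on HepG2 cells (Homo sapiens) for cytotoxicity, read by MTT assay, with a stated time of 48 h (on this read-out lower numbers stand for stronger inhibition and higher numbers for weaker inhibition), compound 3 reaches only a limit, > 100000 nM. Compound 1 `COc1cc(-c2nnc3n2NC(c2ccco2)C(C(=O)c2ccc(F)c(F)c2)S3)cc(OC)c1OC`, with 3,4-difluorophenyl in that place, gives 52400 nM. Compound 2 `COc1cc(-c2nnc3n2NC(c2ccco2)C(C(=O)c2ccco2)S3)cc(OC)c1OC`, bearing furan-2-yl there, likewise gives only a limit, > 100000 nM. Compound 4 `COc1cc(-c2nnc3n2NC(c2ccco2)C(C(=O)c2ccc([N+](=O)[O-])cc2)S3)cc(OC)c1OC` differs from compound 3 by nitro in place of hydroxy on an aromatic carbon. The measured steps that bear on this change are an at least 1.9-fold higher number from compound 1 to compound 3 (0.28 log units; that floor lies within the scatter) and an at least 1.9-fold higher number from compound 1 to compound 2 (0.28 log units; that floor lies within the scatter), while a step that the two limits leave unreadable from compound 2 to compound 3; the limit of > 100000 nM in this assay, at which 2 of the 3 values shown sit, shows where most of the series sits. Going by the values given here, no measured step reaches beyond the scatter, so the expected step of an at least 1.2-fold lower number from compound 3 to compound 4 (0.09 log units; that floor lies within the scatter) is none beyond it. Compound 4 is therefore estimated at 80000 nM, between 30000 nM and 200000 nM.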

Compound 4, half-maximal inhibitory concentration: 87800 nM
Compound 4: the middle estimate sits 1.1-fold (0.04 log units) below what was measured; low and high end bracket the measured number.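

With nitro in place of hydroxy, compound 4 gives a number rather than a limit in this assay, but the change amounts only to an at least 1.1-fold lower number from compound 3 to compound 4 (0.05 log units; that floor lies within the scatter), and the furan-2-yl comparison to an at least 1.1-fold lower number from compound 2 to compound 4 (0.05 log units; that floor lies within the scatter). Against the 3,4-difluorophenyl group, the reading is a 1.7-fold higher number from compound 1 to compound 4 (0.22 log units; within the scatter), so the two numbers measured at this position do not separate. The new value leaves the series close to one mark: the limit of > 100000 nM in this assay, at which 2 of the 4 values shown sit.

Going by these compounds, whether an amine or a carboxylic acid in place of the nitro would move the number beyond the scatter stays open.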